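Cyclobutyl Amide to Propyl Carbamate on a Shared Core

The source may report more compounds than this note shows. Statements on the series, on what has been measured and on what is new or still open speak of the compounds shown alone.

Of the compounds shown here, three have so far been tested in a functional assay on WI-38 VA13 cells (Homo sapiens) for cytotoxicity; on this read-out higher numbers stand for an effect only at larger amounts of compound and lower numbers for an effect already at smaller amounts. Compound 1 `O=C(Nc1ccc2nc(NC(=O)C3CCCCC3)sc2c1)c1ccccc1Oc1ccccc1` gives 0.1 ug/mL in this assay. Compound 2 `O=C(Nc1nc2ccc(N/C(S)=N/C3=CC4OCCOC4C=C3)cc2s1)C1CCCCC1` gives 1.6 ug/mL in this assay. Compound 3 `O=C(Nc1ccc2nc(NC(=O)C3CCC3)sc2c1)c1c(Cl)cccc1Cl` gives 0.013 ug/mL in this assay, the lowest of the three numbers; its gap to compound 1 and its larger gap to compound 2 both lie beyond the usual scatter, so compound 3 is the one that acts at the smallest amount among these three.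

Compound 4 `CCCOC(=O)Nc1nc2ccc(NC(=O)c3c(Cl)cccc3Cl)cc2s1` keeps the core of compound 3 and differs from it in a single place: propoxy in place of cyclobutyl on a carbonyl carbon. For the measured compounds named here, no pair of measured compounds shows this same change, so nothing measured tells how large its effect in this assay will be. A modest step toward a higher number is expected, and the expected step is a 2.3-fold higher number from compound 3 to compound 4 (0.36 log units; beyond the scatter). Compound 4 is therefore estimated at 0.03 ug/mL in this assay, with a range from 0.005 ug/mL to 0.2 ug/mL to cover this uncertainty.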

Compound 4, half-maximal effective concentration: 0.0025 ug/mL
Estimate against measurement, compound 4: 12-fold (1.08 log units) above; the measured number lies below the stated range.
By their numbers in this assay, from the lowest: compound 4; then compound 3; then compound 1; then compound 2.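

Replacing the ring with an open chain on this carbonyl carbon, which turns (cyclobutylcarbonyl)amino into (propoxycarbonyl)amino, carries no penalty in this assay: the change gives a 5.2-fold lower number from compound 3 to compound 4 (0.72 log units; beyond the scatter). A lower number here means an effect at smaller amounts, so this position accepts a group with no ring and with an added oxygen, and compound 4 now has the lowest number of the four. Nothing available explains why the number falls with this change.

The ring leaves and the oxygen enters in the same step, so the compounds shown cannot tell which of the two accounts for the shift. A butyl group on the same carbonyl carbon would separate these two changes, and a pentyloxy group would show whether a longer chain is also accepted here.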